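Replacing imidazole with tolylethyl at the pyridine position

A few compounds are considered here, and "the series" means these few. Any claim that something is new, unique, unknown or untested is made for them only; others in the source may bear on it.

Measured compounds:
Compound 1 `CC(C(=O)NCc1ccc(C(F)(F)F)nc1-c1ccc2c(c1)OCCO2)c1ccc(NS(C)(=O)=O)c(F)c1` — 5 nM
Compound 2 `CC(C(=O)NCc1ccc(C(F)(F)F)nc1-c1ccco1)c1ccc(NS(C)(=O)=O)c(F)c1` — 5.8 nM
Compound 3 `CC(C(=O)NCc1ccc(C(F)(F)F)nc1-n1ccnc1)c1ccc(NS(C)(=O)=O)c(F)c1` — 36.1 nM

In an assay on CHO cells for antagonist activity at transient receptor potential cation channel subfamily V member 1 (Homo sapiens), read by FLIPR (on this read-out lower numbers stand for stronger inhibition and higher numbers for weaker inhibition), compound 3 gives the highest number of the three. The step of a 7.2-fold higher number from compound 1 to compound 3 (0.86 log units; beyond the scatter) and the step of a 6.2-fold higher number from compound 2 to compound 3 (0.79 log units; beyond the scatter) both go beyond the scatter, whereas a 1.2-fold higher number from compound 1 to compound 2 (0.06 log units; within the scatter) stays within it. Compound 4 `Cc1ccc(CCc2nc(C(F)(F)F)ccc2CNC(=O)C(C)c2ccc(NS(C)(=O)=O)c(F)c2)cc1` carries 2-(4-methylphenyl)ethyl in place of 1H-imidazol-1-yl on an aromatic carbon. Within the data shown here, no measured step uses this entering group, but both carbon-attached aryl groups in compound 1 and compound 2 sit well below compound 3, so a return toward that region is expected. The estimated step is a 4.5-fold lower number from compound 3 to compound 4 (0.65 log units; beyond the scatter). Compound 4 is thus expected at 8 nM, within 2.5 nM to 30 nM, in this assay.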

Compound 4, inhibition constant: 0.6 nM
Estimate against measurement, compound 4: 13-fold (1.12 log units) above, and the stated range ends above it.
By their numbers in this assay, from the lowest: compound 4; then compounds 1 and 2 (each within the scatter of the next); then compound 3.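

In this assay the change to 2-(4-methylphenyl)ethyl on this aromatic carbon next to the ring nitrogen brings a 60-fold lower number from compound 3 to compound 4 (1.78 log units; beyond the scatter) and does more than undo the loss seen with the imidazole. It also passes both directly attached rings, with a 9.7-fold lower number from compound 2 to compound 4 (0.99 log units; beyond the scatter) and an 8.3-fold lower number from compound 1 to compound 4 (0.92 log units; beyond the scatter) making compound 4 the most potent of the four, so a ring set off by a chain outdoes those rings here. Nothing available accounts for this gain. Open, going by these compounds, is whether the chain or the ring's methyl group matters, and whether a longer propyl chain or an amine linker would hold this level.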